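Capping a Hydroxyl: From Compound 3 to Compound 4

The source may hold more compounds than are shown below. What is called first, only, known or untested is meant among the compounds shown, and "the series" means these compounds.

Three compounds share one read-out, an ADME assay on cells (Hepatocyte, Homo sapiens) for metabolic stability, read by LC-MS, with a stated time of 120 min; on this read-out higher numbers stand for fast clearance and lower numbers for slow clearance. Compound 1 `CNC(=O)c1cc(C(=O)N[C@H]2[C@@H]3COC[C@@H]32)c([C@@H](C)c2ccccc2)o1` comes out at < 0.45 mL/min, which is a limit of the assay rather than a number. Compound 2 `CNC(=O)c1cc(C(=O)N[C@H]2[C@@H]3C[C@@H](O)C[C@@H]32)n([C@@H](C)c2cccc(Cl)c2)n1` sits at < 0.45 mL/min, again a limit. Compound 3 `CNC(=O)c1cc(C(=O)N[C@H]2CC[C@H](O)CC2)n([C@@H](C)c2ccccc2)n1` stands at < 0.5 mL/min, also a limit. Taken together, the limit of < 0.45 mL/min in this assay, at which 2 of the 3 values shown sit, and the limit of < 0.5 mL/min in this assay, at which 1 of the 3 values shown sits, show that all three gather at the floor of this assay. Compound 4 `CNC(=O)c1cc(C(=O)N[C@H]2CC[C@H](OC)CC2)n([C@@H](C)c2ccccc2)n1` is compound 3 with a single change: methyl in place of hydrogen on an oxygen on a saturated carbon. No measured pair differs in just one place, so this step has no precedent among these compounds. The expected step is small, an at least 1.2-fold higher number from compound 3 to compound 4 (0.07 log units; that floor lies within the scatter), not beyond the usual scatter. Compound 4 is therefore estimated at 0.6 mL/min, within 0.3 mL/min to 1.5 mL/min.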

Compound 4, intrinsic clearance in a liver preparation (reported as CLH), per the amount of preparation that the assay uses: < 0.45 mL/min
Compound 4 gave a limit, no number (the forecaster's own chance of this, stated with the estimate: 50%); middle value at least 1.3-fold (0.12 log units) from the limit.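

Compound 3 and compound 4 each give a limit rather than a number, so the step between them cannot be read. From the compounds shown here alone, whether hydroxy to methoxy changes clearance at all remains open.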